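Opening a ring on the amine chain of a sulfonamide

This account rests on a few compounds, and the source may have more. Where it says the series, first, only, none or still open, it means among the compounds named here.

Measured compounds:
- compound 1 `CC(=O)SCC(=O)c1ccc(NS(=O)(=O)c2ccc(OC3CCCN(C)C3)cc2)nc1`: in a functional assay on HCT-116 cells (Homo sapiens) for cytotoxicity (on this read-out higher numbers stand for an effect only at larger amounts of compound and lower numbers for an effect already at smaller amounts), compound 1 gives 3700 nM
- compound 2 `CC(=O)SCC(=O)c1ccc(NS(=O)(=O)c2ccc(OCCCN3CCCCC3)cc2)nc1`: in this assay compound 2 gives 1000 nM

Among these two, compound 2 has the lower number, and the step of a 3.7-fold lower number from compound 1 to compound 2 (0.57 log units; beyond the scatter) lies beyond the scatter. Compound 3 `CC(=O)SCC(=O)c1ccc(NS(=O)(=O)c2ccc(OCCCCN(C)C)cc2)nc1` keeps the chain of compound 2 but carries the change ((dimethylamino)methyl in place of piperidin-1-yl on a saturated chain carbon, three bonds along the chain from an oxygen on an aromatic ring). Among the compounds with values here, no measured step covers this kind of change; the only step known, a 3.7-fold lower number from compound 1 to compound 2 (0.57 log units; beyond the scatter), rebuilt the whole chain rather than opening its terminal ring. The expected step of a 1.5-fold higher number from compound 2 to compound 3 (0.18 log units; within the scatter) is therefore small and uncertain. Compound 3 is estimated at 1500 nM, in the range 500 nM to 4500 nM.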

Compound 3, half-maximal effective concentration: 280 nM
Compound 3: the middle estimate sits 5.4-fold (0.73 log units) above what was measured; measured number below the stated range.
By their numbers in this assay, from the lowest: compound 3; then compound 2; then compound 1.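

In this assay, putting (dimethylamino)methyl in place of piperidin-1-yl gives a 3.6-fold lower number from compound 2 to compound 3 (0.55 log units; beyond the scatter) beyond what ring removal alone might have been expected to do, so the end of this chain clearly influences the read-out. Set against the 1-methylpiperidin-3-yl of the first compound, the 4-(dimethylamino)butyl group gives a 13-fold lower number from compound 1 to compound 3 (1.12 log units; beyond the scatter) as the largest step in this small set. Nothing shown here accounts for either step. Still open, going by these compounds, is whether a pyrrolidine ring, a morpholine ring or a diethylamino group at the chain end would move the number the same way, and what a shorter or longer chain would do.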